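A Urea Tail in Place of Cyclopropyl

The compounds below may be only part of what the source reports. "The series", "measured", "known", "first", "only" and "open" are said of these compounds alone.

Measured compounds:
compound 1 `COc1ncc(-c2ccc3nc(NC4CC4)sc3c2)cc1NS(=O)(=O)c1ccc(F)cc1` — 1500 nM
compound 2 `CCN(CC)CCNC(=O)Nc1nc2ccc(-c3cnc(OC)c(NS(=O)(=O)c4ccc(C)cc4)c3)cc2s1` — 360 nM
compound 3 `O=S(=O)(Nc1cc(-c2ccc3nc(NC4CC4)sc3c2)cnc1Cl)c1ccc(F)cc1` — "not determined" (no result reported)

The three compounds share a core and were tested in a functional assay on U-87MG ATCC cells for antiproliferative activity against U-87 MG (Homo sapiens), read by MTT assay, with a stated time of 72 h; a lower number here means a stronger inhibitor, a higher number a weaker inhibitor. Within the data shown here, compound 1 gives 1500 nM, and that is the highest of the two numbers known; compound 2 gives 360 nM, a lower number that lies beyond the scatter, though compound 2 differs from compound 1 in more than one place, so no single step can be read from that pair. Compound 3 gives "not determined" (no result reported).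

The step considered here leads from compound 1 to compound 4 `COc1ncc(-c2ccc3nc(NC(=O)NCCN(C)C)sc3c2)cc1NS(=O)(=O)c1ccc(F)cc1`. The change is (2-(dimethylamino)ethyl)carbamoyl in place of cyclopropyl on a nitrogen on an aromatic ring. Among the measured compounds shown here, no measured pair isolates this change. Compound 2, which carries a related carbamoyl tail, shows a lower number than compound 1, so compound 4 is expected to move in the same direction, with a step from compound 1 to compound 4 of a 3.3-fold lower number from compound 1 to compound 4 (0.52 log units; beyond the scatter) beyond the scatter. Compound 4 is therefore estimated at 450 nM, with a range from 150 nM to 1400 nM.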

Compound 4, half-maximal inhibitory concentration: 1020 nM
The estimate for compound 4 lay 2.3-fold (0.36 log units) below the measured number, and the stated range covers the measured number.
By their numbers in this assay, from the lowest: compound 2; then compounds 4 and 1 (each within the scatter of the next).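

In this assay the change on this nitrogen on an aromatic ring can now be read on its own: the step is a 1.5-fold lower number from compound 1 to compound 4 (0.17 log units; within the scatter) and stays within the scatter. Putting (2-(dimethylamino)ethyl)carbamoyl in place of cyclopropyl, a swap of a small carbon ring for a longer ring-free group, therefore leaves the number indistinguishable from that of compound 1 in this read-out, so this position accepts the larger group without a clear gain or loss. No evidence is available to explain this outcome.

Going by these compounds, whether a longer chain between the carbamoyl and the terminal amine would separate from compound 1 remains open. So does the effect of a morpholine or a carboxylic acid at the end of the chain.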